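A few compounds are considered here, and "the series" means these few. Any claim that something is new, unique, unknown or untested is made for them only; others in the source may bear on it.

Measured so far:
compound 1 `Cc1ccccc1NNC(=O)c1ccc(NS(=O)(=O)c2cnc(O)nc2O)cc1`, 14500 nM
compound 2 `O=C(NNc1cccc(Cl)c1)c1ccccc1NS(=O)(=O)c1cnc(O)nc1O`, 5290 nM

In a functional assay on A549 cells (Homo sapiens) for antiproliferative activity, read by MTT assay, with a stated time of 24 h (a higher number here means a weaker inhibitor, a lower number a stronger inhibitor), compound 1 gives 14500 nM, the higher of the two numbers recorded. Within the data shown here, compound 2 gives 5290 nM, a lower number, and the gap between them lies beyond the scatter of repeated runs; no single-point step connects these two structures, so nothing more is drawn from that pair.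

Compound 3 `Cc1ccccc1C(=O)NNC(=O)c1ccc(NS(=O)(=O)c2cnc(O)nc2O)cc1` is not yet measured. It differs from compound 1 in one place: (2-methylphenyl)carbonyl in place of 2-methylphenyl on an amine nitrogen. Among the measured compounds shown here, no measured pair shows the effect of this change, so the step is expected to be small, with a slight lean toward a higher number, and could well stay within the scatter.

On that basis compound 3 is expected to give about 18000 nM in this assay, within the range 6000 nM to 50000 nM, which corresponds to an estimated step of a 1.2-fold higher number from compound 1 to compound 3 (0.09 log units; within the scatter).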

Compound 3, half-maximal inhibitory concentration: 15100 nM
For compound 3 the middle estimate is 1.2-fold (0.08 log units) above the measured one, within the range that was stated.
By their numbers in this assay, from the lowest: compound 2; then compounds 1 and 3 (each within the scatter of the next).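

In this assay the exchange of 2-methylphenyl for (2-methylphenyl)carbonyl on an amine nitrogen amounts to a 1.0-fold higher number from compound 1 to compound 3 (0.02 log units; within the scatter) and so gives no readable change. Among these compounds, this is the first single-place comparison, and it shows that this nitrogen accepts a carbonyl between itself and the 2-methylphenyl ring without a shift in the antiproliferative read-out beyond the scatter. No measured evidence bears on why the number holds steady here.

Going by these compounds, only one substituent has been compared at this nitrogen, so it remains open whether the flat result would hold for a simple acetyl group, a longer alkyl chain or a group carrying a carboxylic acid. On these data alone, compound 2 differs from compound 1 and compound 3 in more than one place, so what sets its number apart also remains open.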